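The compounds below may be only part of what the source reports. "The series", "measured", "known", "first", "only" and "open" are said of these compounds alone.

Of the compounds shown here, three have been measured in a functional assay on MCF7 cells (Homo sapiens) for antiproliferative activity; on this read-out lower numbers stand for stronger inhibition and higher numbers for weaker inhibition. Compound 1 `Cc1c(O)ccc2cc(-n3cc(-c4ccccc4)nn3)c(=O)oc12` gives 25200 nM in this assay. Compound 2 `CC(=O)Oc1ccc2cc(-n3cc(-c4ccccc4)nn3)c(=O)oc2c1C`, which carries an acetyl on the ring oxygen, gives 40800 nM in this assay. Compound 3 `CO[C@@H]1[C@@H](O)[C@@H](O)[C@H](Oc2ccc3c(c2C)OC(=O)C(n2cc(/C=C/c4ccccc4)nn2)C3)OC1(C)C` gives 14600 nM in this assay. Within the data shown here, the one step between compounds that differ in a single place is a 1.6-fold higher number from compound 1 to compound 2 (0.21 log units; within the scatter). On the numbers shown, compound 2 stands at the highest of the three, although compound 1 lies within the scatter of it; only compound 3, with its lower number, lies beyond the scatter.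

Compound 4 `CC(=O)Oc1ccc2cc(-n3cc(-c4c[nH]c5ccccc45)nn3)c(=O)oc2c1C` has not yet been measured. It differs from compound 2 by 1H-indol-3-yl in place of phenyl on an aromatic carbon. Among the measured compounds shown here, no measured step bears on this exchange: the single step available alters the substituent on the oxygen and was within the scatter, and compound 3 differs from compound 2 in several places at once, so its number cannot be traced to any one change. With nothing measured on the exchange of the aromatic group, the expectation for compound 4 is a number near that of compound 2, with no step beyond the scatter, as expressed by a 1.4-fold lower number from compound 2 to compound 4 (0.13 log units; within the scatter). Compound 4 is therefore estimated to give 30000 nM in this assay, within a range from 8000 nM to 100000 nM.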

Compound 4, half-maximal inhibitory concentration: 7450 nM
Estimate against measurement, compound 4: 4.0-fold (0.60 log units) above; the measured number lies below the stated range.
By their numbers in this assay, from the lowest: compounds 4, 3, 1 and 2 (each within the scatter of the next, the first and the last beyond it).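

In this assay, among these compounds, a 5.5-fold lower number from compound 2 to compound 4 (0.74 log units; beyond the scatter) is the first step between single-place neighbours that lies beyond the scatter. Among the compounds shown here, it shows that the group on the aromatic carbon of the five-membered aromatic ring with 3 nitrogen can shift the antiproliferative read-out, whereas the one earlier step, a 1.6-fold higher number from compound 1 to compound 2 (0.21 log units; within the scatter), at the substituent on the oxygen, stayed within the scatter. The 1H-indol-3-yl brings more heavy atoms than phenyl, a five-membered aromatic ring and a hydrogen-bond donor, but this single exchange changes all of these at once, and no measurement at hand accounts for the lower number.

The compounds shown leave open which of those features carries the step, a question that a naphthyl group or a 1-methylindol-3-yl group at the same place would address, as each keeps two fused rings but has no indole ring hydrogen on nitrogen. They also leave open whether the step from phenyl to 1H-indol-3-yl would hold with a free hydroxyl in place of the acetyl on the oxygen, as in compound 1.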